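Hydroxy in place of fluoro on the pendant ring

A few compounds are considered here, and "the series" means these few. Any claim that something is new, unique, unknown or untested is made for them only; others in the source may bear on it.

The series shares one core with a substituted phenyl arm on the exocyclic double bond: compound 1 `O=C1/C(=C/c2ccc(Br)cc2)NS(=O)(=O)c2ccccc21`, compound 2 `O=C1/C(=C/c2ccc(Cl)cc2)NS(=O)(=O)c2ccccc21`, compound 3 `O=C1/C(=C/c2cccc(F)c2)NS(=O)(=O)c2ccccc21` and the not yet measured compound 4 `O=C1/C(=C/c2cccc(O)c2)NS(=O)(=O)c2ccccc21`. In an assay for inhibition of alkaline phosphatase, tissue-nonspecific isozyme (Homo sapiens), read by spectrophotometry, with stated times of 10 min and 20 min (a lower number here means a stronger inhibitor, a higher number a weaker inhibitor), compound 1 gives 1430 nM, compound 2 gives 250 nM and compound 3 gives 3190 nM, the highest of the three numbers, with compound 1 nearest and compound 2 furthest. The measured steps are a 5.7-fold lower number from compound 1 to compound 2 (0.76 log units; beyond the scatter), a 2.2-fold higher number from compound 1 to compound 3 (0.35 log units; beyond the scatter) and a 13-fold higher number from compound 2 to compound 3 (1.11 log units; beyond the scatter). Among the compounds with values here, every one of them exchanges one halogen for another or shifts the halogen on the ring; none introduces a hydroxy, so no step bears directly on the change at hand.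

Compound 4 differs from compound 3 by hydroxy in place of fluoro on an aromatic carbon. With no hydroxy comparison in the series, the only loose analogy is the single-atom swap on an aromatic carbon seen between compound 1 and compound 2. The direction is open, and compound 4 is expected to give 3000 nM, between 800 nM and 12000 nM, an expected step of a 1.1-fold lower number from compound 3 to compound 4 (0.03 log units; within the scatter) that need not exceed the scatter.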

Compound 4, half-maximal inhibitory concentration: 3570 nM
Compound 4: middle estimate off by 1.2-fold (0.08 log units), on the low side, within the range that was stated.
By their numbers in this assay, from the lowest: compound 2; then compound 1; then compounds 3 and 4 (each within the scatter of the next).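

In this assay, within the data shown here, the first hydroxy comparison gives a 1.1-fold higher number from compound 3 to compound 4 (0.05 log units; within the scatter), so on this aromatic carbon, meta to a large group, the entry of a hydrogen-bond donor and acceptor in place of fluoro comes with no readable shift. Compound 4 therefore stands with compound 3 apart from the 4-halophenyl compounds, with a 14-fold higher number from compound 2 to compound 4 (1.15 log units; beyond the scatter) and a 2.5-fold higher number from compound 1 to compound 4 (0.40 log units; beyond the scatter), so the gap to those arms holds with either fluoro or hydroxy here. No supporting data bear on this result.

Open, from the compounds shown here alone, is whether a methoxy, an amine or a carboxylic acid on this aromatic carbon would also stay level with compound 3 and compound 4. The steps to compound 1 and compound 2 change group and place together, so the two contributions cannot be separated from them.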